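The source may report more compounds than this note shows. Statements on the series, on what has been measured and on what is new or still open speak of the compounds shown alone.

Compound 1 `CNc1cc(Nc2cc(F)cc(F)c2OC)nn2c(C(=O)NCC(C)(C)CO)cnc12` gives 24%
Compound 2 `CNc1cc(Nc2cc(C)cc(C)c2)nn2c(C(N)=O)cnc12` gives 6%
Compound 3 `CNc1cc(Nc2cccc(C(C)(C)C)c2)nn2c(C(N)=O)cnc12` gives 3%

These three values come from an ADME assay on microsomes from liver (Mus musculus) for metabolic stability, read by mass spectrometry, with a stated time of 10 min, tested at 0.5 uM (a higher number here means that more of the compound is left, a lower number that less of the compound is left), and do not sit evenly. Compound 2 at 6% and compound 3 at 3% lie within the scatter of each other, so neither can be ranked over the other. Compound 1 at 24% stands beyond the scatter above compound 2, which leaves compound 2 in the low part of this small set.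

Compound 4 `CNc1cc(Nc2cc(C)cc(C)c2)nn2c(C(=O)NC3CC3)cnc12` changes compound 2 in one place, by cyclopropyl in place of hydrogen on an amide-type nitrogen and so carries cyclopropyl in place of hydrogen on an amide-type nitrogen. Going by the values given here, no measured pair isolates this change. Compound 1 (at 24%) also bears a group on that nitrogen, but it differs from compound 2 elsewhere too, so it offers only a loose hint of a rise. Expected in this assay is a number 4 percentage points higher from compound 2 to compound 4 (within the scatter) as a slight rise that stays within the scatter. Compound 4 is estimated at 10% (range 3% to 30%).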

Compound 4, percent of the compound remaining: 1%
Beside the measured number, compound 4's estimate is 9 percentage points above it, and the stated range ends above it.
By their numbers in this assay, from the lowest: compounds 4, 3 and 2 (each within the scatter of the next); then compound 1.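

In this assay, going by these compounds alone, cyclopropyl in place of hydrogen on an amide-type nitrogen gives a number 5 percentage points lower from compound 2 to compound 4 (within the scatter), and this is the first pair in which this one change stands alone. At this position, then, cyclopropyl does not move the number beyond the scatter of the parent carbamoyl compound, and both compounds stay in the low part of the set. No measurement shown offers a reason for this result.

From the compounds shown here alone, what other groups on this nitrogen would do stays open, for example an amine, a carboxylic acid or a longer chain. Going by these compounds, it is also open whether cyclopropyl would give the same result on a compound that starts from a higher number, since the values of this pair lie too low to show much of a further fall.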